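From Cyclohexyl to Naphthalen-2-yl on the Shared Carbon

The compounds below may be only part of what the source reports. "The series", "measured", "known", "first", "only" and "open" are said of these compounds alone.

Three compounds with a shared core have numbers in a functional assay on HeLa cells (Homo sapiens) for inhibition, read by MTT assay, with a stated time of 48 h; on this read-out lower numbers stand for stronger inhibition and higher numbers for weaker inhibition. Compound 1 `COc1ccc(C(c2c[nH]c3ccc(Br)cc23)c2c[nH]c3ccc(Br)cc23)c(OC)c1` gives 63200 nM, compound 2 `COc1ccc(C(c2c[nH]c3ccc(Br)cc23)c2c[nH]c3ccc(Br)cc23)cc1OC` gives 6100 nM, and compound 3 `Brc1ccc2[nH]cc(C(c3c[nH]c4ccc(Br)cc34)C3CCCCC3)c2c1` gives 3200 nM. Two steps set the picture: there is a 20-fold lower number from compound 1 to compound 3 (1.30 log units; beyond the scatter), and only a 1.9-fold lower number from compound 2 to compound 3 (0.28 log units; within the scatter), so compound 3 is far from compound 1 yet level with compound 2.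

Compound 4 `Brc1ccc2[nH]cc(C(c3ccc4ccccc4c3)c3c[nH]c4ccc(Br)cc34)c2c1` has not been measured. It differs from compound 3 at one place: naphthalen-2-yl in place of cyclohexyl on a saturated chain carbon bound to two aromatic carbons. Among the compounds with values here, no tested compound carries naphthalen-2-yl, so the evidence is indirect. The two dimethoxyphenyl compounds are separated by a 10-fold lower number from compound 1 to compound 2 (1.02 log units; beyond the scatter), which shows that aromatic groups at this carbon can give very different numbers. Compound 2, at 6100 nM, suggests an aromatic group can stay close to compound 3, while compound 1, at 63200 nM, warns of a much weaker result.

In this assay, a modest rise is therefore expected, namely a 2.2-fold higher number from compound 3 to compound 4 (0.34 log units; beyond the scatter). Compound 4 is estimated at 7000 nM, with an expected range of 2000 nM to 30000 nM.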

Compound 4, half-maximal inhibitory concentration: 4300 nM
For compound 4 the middle estimate is 1.6-fold (0.21 log units) above the measured one; measured number inside the range.
By their numbers in this assay, from the lowest: compounds 3, 4 and 2 (each within the scatter of the next); then compound 1.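

Compound 4 shows that this carbon can carry naphthalen-2-yl, with its two aromatic rings, and still give a number level with the non-aromatic cyclohexyl group in this assay: there is a 1.3-fold higher number from compound 3 to compound 4 (0.13 log units; within the scatter), and likewise a 1.4-fold lower number from compound 2 to compound 4 (0.15 log units; within the scatter). Among these four compounds, having an aromatic group at this carbon does not by itself bring the weak result of compound 1, which remains the one compound apart, with a 15-fold lower number from compound 1 to compound 4 (1.17 log units; beyond the scatter). Nothing measured here explains why these groups give such similar numbers or why the 2,4-dimethoxyphenyl compound stands apart.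

Still open, from the compounds shown here alone, is whether a group carrying an amine or a carboxylic acid would stay level at this carbon. A longer chain in place of the ring is equally untested by the compounds shown.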